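Nitro to chloro on the aryl ring of the spiro-isoxazoline series

A few compounds are considered here, and "the series" means these few. Any claim that something is new, unique, unknown or untested is made for them only; others in the source may bear on it.

Three compounds share one core and differ only in the aryl group on the carbon with a double bond to nitrogen. Compound 1 `COc1ccc(C2=NO[C@]3(C2)C(=O)O[C@@H]2[C@H]3CC[C@H](C)[C@]3(O)C=CC(=O)[C@@]23C)cc1` gives 1.47 in a physicochemical assay for lipophilicity; a higher number here means a more lipophilic compound, a lower number a more polar compound. Compound 2 `C[C@H]1CC[C@@H]2[C@@H](OC(=O)[C@]23CC(c2ccc(O)cc2)=NO3)[C@]2(C)C(=O)C=C[C@@]12O` gives 0.932, and compound 3 `C[C@H]1CC[C@@H]2[C@@H](OC(=O)[C@]23CC(c2ccccc2[N+](=O)[O-])=NO3)[C@]2(C)C(=O)C=C[C@@]12O` gives 1.37. Compound 3 stands second highest of the three numbers: its nearest neighbour is compound 1, the step of a number 0.10 log units lower from compound 1 to compound 3 (within the scatter) lying within the scatter, while the step of a number 0.44 log units higher from compound 2 to compound 3 (beyond the scatter) is beyond it. The third step in hand, a number 0.54 log units lower from compound 1 to compound 2 (beyond the scatter), concerns hydrogen in place of methyl on an oxygen on an aromatic ring and has no direct bearing on the change below.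

Compound 4 `C[C@H]1CC[C@@H]2[C@@H](OC(=O)[C@]23CC(c2ccccc2Cl)=NO3)[C@]2(C)C(=O)C=C[C@@]12O` differs from compound 3 in one place: chloro in place of nitro on an aromatic carbon. For the measured compounds named here, none of the measured steps pairs a nitro with a chloro, so there is no step that speaks to this change directly, and any expectation rests on the general behaviour of such swaps rather than on these compounds. The step of a number 0.58 log units higher from compound 3 to compound 4 (beyond the scatter) is expected to be modest and upward, beyond the scatter. Compound 4 is therefore estimated at 1.95, within a range of 1.45 to 2.5.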

Compound 4, partition coefficient: 2.09
The estimate for compound 4 lay 0.14 log units below the measured number, within the range that was stated.
By their numbers in this assay, from the lowest: compound 2; then compounds 3 and 1 (each within the scatter of the next); then compound 4.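

Within the shared core, swapping nitro for chloro on an aromatic carbon ortho to a large group gives in this assay a number 0.72 log units higher from compound 3 to compound 4 (beyond the scatter), the first read-out in the series for a change of this single group with the rest of the aryl ring held fixed. The 2-chlorophenyl compound also separates from the other two aryl groups, with a number 0.62 log units higher from compound 1 to compound 4 (beyond the scatter) and the large a number 1.16 log units higher from compound 2 to compound 4 (beyond the scatter), so compound 4 has the highest number of the four, whereas the 2-nitrophenyl and 4-methoxyphenyl compounds could not be told apart. No measurement in hand accounts for the size of these steps.

The series shown has chloro only at this one place, so it remains open whether the step from nitro would hold on another carbon of the aromatic ring or with a different aryl group on the core. As far as these compounds go, it also remains open where an amine, a carboxylic acid or a methyl group on the same aromatic carbon would fall relative to compound 3 and compound 4.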